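The source may hold more compounds than are shown below. What is called first, only, known or untested is meant among the compounds shown, and "the series" means these compounds.

Compound 2 `O=C(Nc1ccc(Cl)cc1)Nc1nnc(Sc2ncnc3scc(-c4ccncc4)c23)s1` gives 7700 nM in a functional assay on PC-3 cells (Homo sapiens) for antiproliferative activity, read by MTT assay, with a stated time of 48 h (a lower number here means a stronger inhibitor, a higher number a weaker inhibitor), and its only measured companion, compound 1 `Cc1ccc(NC(=O)Nc2nnc(Sc3ncnc4scc(-c5ccncc5)c34)s2)cc1Cl`, gives 4700 nM in this assay, a difference that stays within the scatter. Compound 3 `O=C(Nc1ccc(Cl)c(C(F)(F)F)c1)Nc1nnc(Sc2ncnc3scc(-c4ccncc4)c23)s1` carries trifluoromethyl in place of hydrogen on an aromatic carbon, ortho to a chloro group. Going by the values given here, the one measured step, a 1.6-fold higher number from compound 1 to compound 2 (0.21 log units; within the scatter), shows that changing substitution on this phenyl did not move the number beyond the scatter, so no step beyond the scatter is expected for compound 3 either, as a 1.4-fold lower number from compound 2 to compound 3 (0.15 log units; within the scatter). Compound 3 is therefore estimated at 5500 nM, within 2200 nM to 14000 nM.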

Compound 3, half-maximal inhibitory concentration: 12100 nM
Beside the measured number, compound 3's estimate is 2.2-fold (0.34 log units) below it, and the stated range covers the measured number.
By their numbers in this assay, from the lowest: compounds 1, 2 and 3 (each within the scatter of the next, the first and the last beyond it).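

Trifluoromethyl in place of hydrogen brings a 1.6-fold higher number from compound 2 to compound 3 (0.20 log units; within the scatter), so in this assay this aromatic carbon takes a group of four heavy atoms with no change beyond the scatter. The 4-chloro-3-(trifluoromethyl)phenyl group in place of 3-chloro-4-methylphenyl brings a 2.6-fold higher number from compound 1 to compound 3 (0.41 log units; beyond the scatter), the only step beyond the scatter among these three compounds, and a modest one. Nothing available explains either step. Going by these compounds, whether an amine or a carboxylic acid on this aromatic carbon would move the number remains open, as does the effect of a methoxy group there.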